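Swapping the furan for a fluoro-methoxyphenyl in a cytotoxicity series

The source may hold more compounds than are shown below. What is called first, only, known or untested is meant among the compounds shown, and "the series" means these compounds.

Of the compounds shown here, three of one series have been tested in an ADME assay on HEK293 cells (Homo sapiens) for cytotoxicity, read by CellTiter-Glo and resazurin assay, with a stated time of 72 h; on this read-out higher numbers stand for an effect only at larger amounts of compound and lower numbers for an effect already at smaller amounts. Compound 1, `CC(=O)Nc1cccc(-c2ccc(C(=O)N(Cc3cccc(OCCCCCC(=O)O)c3)C(C)C)cc2)c1`, gives in this assay only the limit > 26000 nM. Compound 2, `CC(C)N(Cc1cccc(OCCCCCC(=O)O)c1)C(=O)c1ccc(-c2ccoc2)cc1`, also reaches only the limit > 26000 nM in this assay. Compound 3, `CCOC(=O)CCCCCOc1cccc(CN(C(=O)c2ccc(-c3ccoc3)cc2)C(C)C)c1`, likewise gives in this assay just the limit > 26000 nM. The step that the two limits leave unreadable from compound 1 to compound 2 and the step that the two limits leave unreadable from compound 2 to compound 3 cannot be read, since the limit of > 26000 nM in this assay, at which 3 of the 3 values shown sit, covers every value seen so far. Compound 3 therefore stands where every measured compound stands: at that limit, with no number to rank it.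

The next compound, compound 4, is `CCOC(=O)CCCCCOc1cccc(CN(C(=O)c2ccc(-c3cc(F)cc(OC)c3)cc2)C(C)C)c1`. It differs from compound 3 by 3-fluoro-5-methoxyphenyl in place of furan-3-yl on an aromatic carbon. Among the compounds with values here, no measured step involves this exchange, and the two steps that were measured are both unreadable, so there is no basis for expecting a change beyond the scatter in this assay. Because the limit of > 26000 nM in this assay, at which 3 of the 3 values shown sit, holds for all three measured compounds, compound 4 is expected to sit near the same limit, with a step that the limit leaves unreadable from compound 3 to compound 4 estimated from compound 3. Compound 4 is accordingly estimated at 30000 nM, in a range from 13000 nM to 70000 nM.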

Compound 4, half-maximal effective concentration: > 26000 nM
Compound 4 gave a limit, no number (the forecaster's own chance of this, stated with the estimate: 80%); the middle value is on the limit's open side.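

In this assay, within the data shown here, compound 3 and compound 4 both give only a limit, so no step between them can be read, and the same holds across the series: the limit of > 26000 nM in this assay, at which 4 of the 4 values shown sit. The compounds shown leave open at what concentration, if any, each of them would show an effect.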